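Regaining agonist activity from a thiazolyl cyclopropane amide

The source may hold more compounds than are shown below. What is called first, only, known or untested is meant among the compounds shown, and "the series" means these compounds.

Compound 1 `CC(C)CCNCCN(C(=O)[C@@H]1C[C@H]1c1ccccc1)c1ccc(-c2ccccc2)cc1`: 5.1 nM
Compound 2 `CC[C@H](C)[C@H](N)CN(C(=O)[C@@H]1C[C@H]1C1CCCCC1)c1ccc(-c2ccccc2)cc1`: > 25000 nM

In a functional assay for agonist activity at G protein-coupled receptor 88 (Homo sapiens), read by HTRF and cAMP accumulation (on this read-out lower numbers stand for an effect already at smaller amounts and higher numbers for an effect only at larger amounts of compound), compound 1 gives 5.1 nM. For compound 2, the value > 25000 nM is a limit of the assay, not a number, and compound 2 therefore sits at the limit of > 25000 nM in this assay, at which 1 of the 2 values shown sits, the weaker end of what has been measured. Compound 3 `CC[C@H](C)[C@H](N)CN(C(=O)[C@@H]1C[C@H]1c1nc(C)c(C)s1)c1ccc(-c2ccccc2)cc1` differs from compound 2 by 4,5-dimethyl-1,3-thiazol-2-yl in place of cyclohexyl on a saturated ring carbon. Among the compounds with values here, with no directly comparable measured step, the size of this change is uncertain, but compound 3 is expected to be a step from the limit, an at least 62-fold lower number from compound 2 to compound 3 (1.79 log units; beyond the scatter), into the measurable range. Compound 3 is estimated at 400 nM, with a range from 30 nM to 20000 nM.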

Compound 3, half-maximal effective concentration: 3600 nM
Estimate against measurement, compound 3: 9.0-fold (0.95 log units) below, within the range that was stated.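

At this saturated ring carbon of the three-membered ring, 4,5-dimethyl-1,3-thiazol-2-yl in place of cyclohexyl restores a measurable response in this assay, with an at least 6.9-fold lower number from compound 2 to compound 3 (0.84 log units; beyond the scatter). The position therefore decides on its own whether this amino side chain gives a response that can be read. The step has only a lower bound, because compound 2 sits at a limit: the limit of > 25000 nM in this assay, at which 1 of the 3 values shown sits.

Going by these compounds, whether the two methyl groups are needed remains open, since an unsubstituted 1,3-thiazol-2-yl does not appear here. Compound 1 differs from compound 3 in more than one place, so the share of its phenyl group and of its amine chain cannot be separated.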